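Cyano for methoxy on the N-aryl ring of the core

The compounds below may be only part of what the source reports. "The series", "measured", "known", "first", "only" and "open" are said of these compounds alone.

Measured compounds:
compound 1 `CC(C)c1ccc(-n2nc(-c3ccc(C(F)(F)F)cc3O)nc2-c2ccccc2O)cc1` — 69.7%
compound 2 `COc1ccc(-n2nc(-c3ccc(C(F)(F)F)cc3O)nc2-c2ccccc2O)cc1` — 69%

In a functional assay on PC-12 cells (Rattus norvegicus) for cytotoxicity, read by MTT assay, with stated times of 2 h and 24 h, tested at 1 uM (a lower number here means a weaker effect, a higher number a stronger effect of the compound at the concentration tested), compound 1 gives 69.7%. Compound 2 gives 69% in this assay. The step of a number 0.7 percentage points lower from compound 1 to compound 2 (within the scatter) is the only one measured so far, and it is within the scatter; on these two numbers compound 2 and compound 1 cannot be told apart, so compound 2 stands nowhere in particular, level with compound 1.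

Compound 3 `N#Cc1ccc(-n2nc(-c3ccc(C(F)(F)F)cc3O)nc2-c2ccccc2O)cc1` is the next member. It differs from compound 2 by cyano in place of methoxy on an aromatic carbon.

Going by the values given here, the one step that bears on this change is a number 0.7 percentage points lower from compound 1 to compound 2 (within the scatter), an exchange of one group at the same aromatic carbon, and it gave nothing beyond the scatter. Among the compounds with values here, with no further measured step to draw on, the expectation for compound 3 is that the exchange of methoxy for cyano at this carbon also leaves this assay unchanged beyond the scatter: no change at the digits printed from compound 2 to compound 3 (within the scatter). Compound 3 is therefore estimated at 69%, with a range from 55% to 82%.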

Compound 3, a percentage reported as activity, at one concentration (the size of the read-out at that concentration, not a potency): 66.6%
The estimate for compound 3 lay 2.4 percentage points above the measured number, and the stated range covers the measured number.
By their numbers in this assay, from the lowest: compounds 3, 2 and 1 (each within the scatter of the next).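

At this aromatic carbon, para to a large group, this assay now covers a third substituent: cyano in place of methoxy gives a number 2.4 percentage points lower from compound 2 to compound 3 (within the scatter) at this carbon. Cyano in place of isopropyl, the comparison with the other end of the set, gives a number 3.1 percentage points lower from compound 1 to compound 3 (within the scatter) at the same carbon, so isopropyl, methoxy and cyano all read level in this series, and the single exchange seen earlier is no longer the only one without a step beyond the scatter. No accompanying measurement is available that could account for this level reading.

The compounds shown leave open whether an amine, a carboxylic acid or a longer chain at this carbon would give a step beyond the scatter in this assay or would read level with these three groups. They also leave open how much of the reading depends on the rest of the shared core, including the trifluoromethyl group and the two hydroxyl groups, which are the same in all three compounds.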